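Replacing the anilide of compound 1 with a pyrazolyl amide

A few compounds are considered here, and "the series" means these few. Any claim that something is new, unique, unknown or untested is made for them only; others in the source may bear on it.

Compound 1 `CCOC(=O)C1=C(C)NC(C)=C(C(=O)OCC)C1c1ccc(OCC(=O)Nc2c(C)cccc2C)cc1` is the reference point of this set. In a functional assay on the whole organism (strain Wistar) for inhibition, with Rattus norvegicus as the target, read by paw edema, with stated times of 30 min and 3 h, at a dose of 20 mg/kg (a lower number here means less inhibition, a higher number more inhibition at the dose given (going by the name of the read-out)), compound 1 gives 53.9%, the lowest of the three numbers in hand. Compound 2 `CCOC(=O)C1=C(C)NC(C)=C(C(=O)OCC)C1c1ccc(OCC(=O)Nc2nc3ccccc3s2)cc1` gives 65.9% and compound 3 `CCOC(=O)C1=C(C)NC(C)=C(C(=O)OCC)C1c1ccc(OCC(=O)NNC(=O)c2sccc2Cl)cc1` gives 56.3%. The step of a number 12 percentage points higher from compound 1 to compound 2 (beyond the scatter) is the only one beyond the scatter; the step of a number 2.4 percentage points higher from compound 1 to compound 3 (within the scatter) lies within it, as does a number 9.6 percentage points lower from compound 2 to compound 3 (within the scatter). Compound 1 thus stands closest to compound 3 and furthest from compound 2.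

Compound 4 `CCOC(=O)C1=C(C)NC(C)=C(C(=O)OCC)C1c1ccc(OCC(=O)n2nc(C)cc2C)cc1` is not yet measured. It differs from compound 1 in one place: 3,5-dimethyl-1H-pyrazol-1-yl in place of (2,6-dimethylphenyl)amino on a carbonyl carbon. Both measured steps from compound 1 alter the substituent on the amide-type nitrogen while keeping that nitrogen in place; in compound 4 the whole group on the carbonyl carbon is exchanged, so neither measured step is a direct precedent. What the measured steps show is that changes at this end of the molecule move the read-out upward by a modest amount at most or not beyond the scatter. On that basis the expected step of a number 4.1 percentage points higher from compound 1 to compound 4 (within the scatter) is small, upward if anything, and may not exceed the scatter. Compound 4 is therefore estimated to give 58%, with a range from 46% to 70%.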

Compound 4, a percentage reported as inhibition, in the whole organism at one dose (the size of the read-out at that dose, not a potency): 48.5%
For compound 4 the middle estimate is 9.5 percentage points above the measured one, within the range that was stated.
By their numbers in this assay, from the lowest: compounds 4, 1, 3 and 2 (each within the scatter of the next, the first and the last beyond it).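

Exchanging the whole (2,6-dimethylphenyl)amino group for 3,5-dimethyl-1H-pyrazol-1-yl on the carbonyl carbon removes the amide hydrogen and the carbocyclic aromatic ring together, yet in this assay this gives a number 5.4 percentage points lower from compound 1 to compound 4 (within the scatter) and so no change that can be told from the usual scatter. Measured against the hydrazide-type group of compound 3, the same position gives a number 7.8 percentage points lower from compound 3 to compound 4 (within the scatter), whereas a number 17.4 percentage points lower from compound 2 to compound 4 (beyond the scatter) is the widest step in the set and, unlike the other two, separates the pair. Among the compounds shown, an amide hydrogen on this carbonyl carbon is therefore not needed for a read-out in the range of compound 1 and compound 3, and the (1,3-benzothiazol-2-yl)amino group of compound 2 alone stands apart from compound 1 and compound 4.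

No measurement at hand bears on why the numbers fall this way.

On these data alone, it remains open whether a saturated amine such as morpholine on the same carbonyl carbon, or the free carboxylic acid, would stay within this range, and whether the separation of compound 2 holds at other doses.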